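This account rests on a few compounds, and the source may have more. Where it says the series, first, only, none or still open, it means among the compounds named here.

In a functional assay on MDA-MB-231 cells (Homo sapiens) for inhibition, read by MTT assay, with a stated time of 72 h (a lower number here means a stronger inhibitor, a higher number a weaker inhibitor), compound 2 (`Nc1ncnc2c1c(-c1cnc3[nH]ccc3c1)nn2CCCCCCCCC(=O)NO`) gives 11000 nM. Compound 1 (`CNC(=O)CCCCCCCn1nc(-c2cnc3[nH]ccc3c2)c2c(N)ncnc21`) gives 15800 nM and compound 3 (`Nc1nc2cc(-c3nn(CCCC(=O)NO)c4ncnc(N)c34)ccc2o1`) gives 19500 nM. Compound 2 lies within the scatter of both, so the three values form a single group with no meaningful order among them.

The next compound, compound 4 (`Nc1ncnc2c1c(-c1cnc3[nH]ccc3c1)nn2CCCCCC(=O)NO`), differs from compound 2 in one place: hydroxycarbamoyl in place of 3-(hydroxycarbamoyl)propyl on a saturated chain carbon, five bonds along the chain from an aromatic nitrogen. In words, hydroxycarbamoyl stands in place of 3-(hydroxycarbamoyl)propyl on a saturated chain carbon, five bonds along the chain from an aromatic nitrogen.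

Going by the values given here, no measured pair differing in one place covers this change. The nearest evidence is a 1.4-fold lower number from compound 1 to compound 2 (0.16 log units; within the scatter), which concerns the same end of the chain and stays within the scatter. Compound 3 differs from compound 2 in more than one place, so it cannot isolate the change. Even so, the gap to compound 2 stays within the scatter, with compound 3 at 19500 nM. Among the compounds with values here, nothing measured so far therefore points to a direction, and no shift beyond the scatter is expected in this assay.

The expected step is a 1.1-fold higher number from compound 2 to compound 4 (0.04 log units; within the scatter), an estimate that carries wide uncertainty. For compound 4, the estimated value is 12000 nM, with an expected range of 5000 nM to 28000 nM.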

Compound 4, half-maximal inhibitory concentration: > 100000 nM
Compound 4 was reported as a limit; the forecaster's own chance of this, stated with the estimate: 10%; middle value at least 8.3-fold (0.92 log units) from the limit.
By their numbers in this assay, from the lowest: compounds 2, 1 and 3 (each within the scatter of the next). At a limit, above all of these: compound 4.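

In this assay compound 4 is reported as a limit and not a number: the limit of > 100000 nM in this assay, at which 1 of the 4 values shown sits. Up to this point, the one change at the chain end, the step from compound 1 to compound 2, had stayed within the scatter, but hydroxycarbamoyl in place of 3-(hydroxycarbamoyl)propyl at this position gives an at least 9.0-fold higher number from compound 2 to compound 4 (0.95 log units; beyond the scatter), and hydroxycarbamoyl in place of 2-(methylcarbamoyl)ethyl gives an at least 6.3-fold higher number from compound 1 to compound 4 (0.80 log units; beyond the scatter), both beyond the scatter. The position is therefore sensitive to this change on the shared core of compounds 1, 2 and 4, a finding that does not extend to compound 3, which carries 3-(hydroxycarbamoyl)propyl's shorter relative on a different core and so differs from each of them in more than one place.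

Because compound 4 rests on a limit, these steps give only the least size of the loss, and the compounds shown do not tell where along the chain lengths between those of compound 4 and compound 2 the loss sets in. They also leave open whether a longer chain, or a carboxylic acid in place of the hydroxycarbamoyl end, would keep the values of compound 1 and compound 2 on this core.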